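Extending a Side Chain: Expected Plasma Free Fraction of Compound 4

The compounds below may be only part of what the source reports. "The series", "measured", "known", "first", "only" and "open" are said of these compounds alone.

Compound 1 `CC[C@@H](c1ccc(C(=O)O)c(Oc2cccc(Cl)c2)c1F)N1CCC[C@H](n2cc(C)c(=O)[nH]c2=O)C1` gives 0.011 in an ADME assay on a cell-free system (plasma, Homo sapiens) for protein binding, using equilibrium dialysis, with a stated time of 5 h, tested at 10 uM; on this read-out higher numbers stand for a larger free fraction and lower numbers for a smaller free fraction.
Compound 2 `Cc1cn([C@H]2CCCN([C@H](CC(C)C)c3ccc(C(=O)O)c(Oc4cccc(Cl)c4)c3F)C2)c(=O)[nH]c1=O` gives 0.013 in this assay.
Compound 3 `CC[C@H](c1ccc(C(=O)O)c(Oc2cccc(Cl)c2)c1F)N1CCC[C@H](n2cc(C)c(=O)[nH]c2=O)C1` gives < 0.01 in this assay, which is a limit of the assay and not a number.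

Compound 1 has the lowest of the two numbers measured in this assay, with compound 2 the nearest at a step within the scatter; the third value is a limit. Compound 4 `CCC[C@@H](c1ccc(C(=O)O)c(Oc2cccc(Cl)c2)c1F)N1CCC[C@H](n2cc(C)c(=O)[nH]c2=O)C1` differs from compound 1 by methyl in place of hydrogen on a saturated chain carbon, three bonds along the chain from an amine nitrogen in a ring and an aromatic carbon. For the measured compounds named here, no measured step directly covers this change. The step from compound 2 to compound 3, an at least 1.3-fold lower number from compound 2 to compound 3 (0.11 log units; that floor lies within the scatter), touches the same chain but is combined with a change of configuration, which on its own reads an at least 1.1-fold lower number from compound 1 to compound 3 (0.04 log units; that floor lies within the scatter). Neither floor rises beyond the scatter, and compound 2 with its larger chain sits within the scatter of compound 1, so the account expects no step beyond the scatter from compound 1 to compound 4 in this assay. The expected step is a 1.1-fold lower number from compound 1 to compound 4 (0.04 log units; within the scatter). Compound 4 is therefore estimated at 0.01 in this assay, with a range from 0.005 to 0.02.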

Compound 4, unbound fraction: 0.007
Estimate against measurement, compound 4: 1.4-fold (0.15 log units) above; low and high end bracket the measured number.
By their numbers in this assay, from the lowest: compounds 4, 1 and 2 (each within the scatter of the next).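

For the compounds shown here, compound 4 gives the first direct reading of this position: in this assay, going from ethyl to propyl on the chain gives a 1.6-fold lower number from compound 1 to compound 4 (0.20 log units; within the scatter). Methyl in place of hydrogen, three bonds along the chain from an amine nitrogen in a ring and an aromatic carbon, therefore leaves the unbound fraction within the scatter of compound 1. Nothing shown gives a cause for this step.

From the compounds shown here alone, it remains open whether a hydroxyl, an amine, a carboxylic acid or a longer chain at this place would take the unbound fraction beyond the scatter. Going by these compounds alone, the configuration as drawn is the only difference between compound 1 and compound 3. Compound 3 gives < 0.01, a limit and not a number. Going by these compounds, how configuration acts on this chain also stays open.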